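A few compounds are considered here, and "the series" means these few. Any claim that something is new, unique, unknown or untested is made for them only; others in the source may bear on it.

Three compounds that share one core have numbers in a functional assay on HeLa cells (Homo sapiens) for inhibition, read by MTT assay, with a stated time of 72 h; on this read-out lower numbers stand for stronger inhibition and higher numbers for weaker inhibition. Compound 1 (`COc1cc(NC(C)CCCNC(=O)Nc2ccc(Br)cc2)c2ncccc2c1`) gives 20000 nM, compound 2 (`COc1cc(NC(C)CCCNC(=O)NNC(=O)Nc2ccc(Br)cc2)c2ncccc2c1`) gives 101000 nM, and compound 3 (`COc1cc(NC(C)CCCNC(=O)Nc2ccc(C(F)(F)F)cc2)c2ncccc2c1`) gives 8300 nM, the lowest number of the three. Compound 4 (`COc1cc(NC(C)CCCNC(=O)NNC(=O)Nc2cccc(Cl)c2)c2ncccc2c1`) has not yet been measured. Moving from compound 3 to compound 4 puts ((3-chlorophenyl)carbamoyl)amino in place of 4-(trifluoromethyl)phenyl on an amide-type nitrogen. Counted out, the change is this: ((3-chlorophenyl)carbamoyl)amino in place of 4-(trifluoromethyl)phenyl on an amide-type nitrogen.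

Among the measured compounds shown here, the closest precedent is a 12-fold lower number from compound 2 to compound 3 (1.09 log units; beyond the scatter), a large step, since compound 2 carries a ((4-bromophenyl)carbamoyl)amino group of the same kind as the one entering compound 4. Compound 4 runs that step in the opposite direction. The modest 5.1-fold higher number from compound 1 to compound 2 (0.70 log units; beyond the scatter) points the same way, towards a higher number when the longer group enters. For the measured compounds named here, the modest 2.4-fold lower number from compound 1 to compound 3 (0.38 log units; beyond the scatter) shows that a swap on the aromatic ring can also shift the number, but no measured compound carries chloro, so this part remains open. A large step towards weaker inhibition is therefore expected, estimated as a 7.2-fold higher number from compound 3 to compound 4 (0.86 log units; beyond the scatter). With the value of compound 2, 101000 nM, as the anchor, the estimated value for compound 4 is 60000 nM, with an expected range from 20000 nM to 160000 nM.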

Compound 4, half-maximal inhibitory concentration: 44000 nM
Beside the measured number, compound 4's estimate is 1.4-fold (0.13 log units) above it; low and high end bracket the measured number.
By their numbers in this assay, from the lowest: compound 3; then compound 1; then compound 4; then compound 2.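

In this assay, the ((3-chlorophenyl)carbamoyl)amino group on the amide-type nitrogen again goes with weaker inhibition, with a 5.3-fold higher number from compound 3 to compound 4 (0.72 log units; beyond the scatter) and a 2.2-fold higher number from compound 1 to compound 4 (0.34 log units; beyond the scatter). Across these four compounds, the two that carry the longer carbamoylamino-type group both have higher numbers than the two without it, and none goes against this. What is new is that the aromatic ring still matters once the longer group is in place: 3-chlorophenyl in place of 4-bromophenyl gives a 2.3-fold lower number from compound 2 to compound 4 (0.36 log units; beyond the scatter), so the number at this position depends on the ring as well as on the chain that carries it.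

That ring change alters both the halogen and its place on the ring, so the two effects cannot be separated here, and a 4-chlorophenyl or an unsubstituted phenyl group on the same longer chain would be needed to pull them apart. Nothing shown here explains why the longer group raises the number or why the ring change lowers it.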